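This account rests on a few compounds, and the source may have more. Where it says the series, first, only, none or still open, it means among the compounds named here.

Notes on the side chain series, read in a functional assay on SK-BR-3 cells (Homo sapiens) for antiproliferative activity; a higher number here means a weaker inhibitor, a lower number a stronger inhibitor. Among the compounds with values here, compound 1 `CC(C)=CCc1cc(C(=O)Nc2cc3ccc(OCCCNC(C)(C)C)c(C)c3oc2=O)ccc1O` gives 660 nM, the only true number so far. As far as these compounds go, compound 2 `CC(C)=CCc1cc(C(=O)Nc2cc3ccc(OCCCN(C)c4ccccc4)c(C)c3oc2=O)ccc1O` gives > 50000 nM, which is a limit of the assay and not a number, so its exact position is unknown.

Compound 3 `CC(C)=CCc1cc(C(=O)Nc2cc3ccc(OCCCNC(C)(C)c4ccccc4)c(C)c3oc2=O)ccc1O` differs from compound 2 by (1-methyl-1-phenylethyl)amino in place of methyl(phenyl)amino on a saturated chain carbon, three bonds along the chain from an oxygen on an aromatic ring: (1-methyl-1-phenylethyl)amino in place of methyl(phenyl)amino, on a saturated chain carbon, three bonds along the chain from an oxygen on an aromatic ring. The entering group keeps the six-membered aromatic ring of compound 2, but otherwise reads like the (tert-butyl)amino group of compound 1, with one methyl exchanged for that ring.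

Within the data shown here, the one measured step bearing on this is an at least 75-fold higher number from compound 1 to compound 2 (1.87 log units; beyond the scatter), a large one, made at the same place. Among the measured compounds shown here, no measured compound yet shows what that ring does on the (tert-butyl)amino framework, so the reversal may be incomplete.

A large move to a lower number in this assay is expected, expressed as the estimated at least 33-fold lower number from compound 2 to compound 3 (1.52 log units; beyond the scatter). For compound 3 the estimate is 1500 nM, with an expected range of 400 nM to 8000 nM.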

Compound 3, half-maximal inhibitory concentration: 960 nM
Compound 3: the middle estimate sits 1.6-fold (0.19 log units) above what was measured, and the stated range covers the measured number.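

In this assay, phenyl in place of methyl on a saturated chain carbon bound to an amine nitrogen and two saturated chain carbons gives a 1.5-fold higher number from compound 1 to compound 3 (0.16 log units; within the scatter), so a six-membered aromatic ring in the side chain does not by itself set compound 2 apart from compound 1 and compound 3. The change from methyl(phenyl)amino to (1-methyl-1-phenylethyl)amino gives an at least 52-fold lower number from compound 2 to compound 3 (1.71 log units; beyond the scatter), but two things differ in this step: the entering group counts 1 hydrogen-bond donor against 0 for the leaving group, and its ring is carried on a carbon rather than on the nitrogen, so the step cannot be credited to either alone. Compound 2 stands at a limit of the assay, so the size of that step is only a bound: the limit of > 50000 nM in this assay, at which 1 of the 3 values shown sits.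

Phenylamino, which keeps the ring on the nitrogen and has a hydrogen on that nitrogen, and methyl(tert-butyl)amino, which has no ring and no such hydrogen, would separate the two differences. As far as these compounds go, how a benzylamino group or a longer chain between the oxygen and the amine would read here remains open.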